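The source may report more compounds than this note shows. Statements on the series, on what has been measured and on what is new or still open speak of the compounds shown alone.

Compound 3 `CNc1ncnc2c(CNc3cc(NC(=O)c4cc(C)on4)ccc3C)cccc12` gives the lowest number of the three measured in a functional assay on A375P cells (Homo sapiens) for cytotoxicity, read by MTT assay, with a stated time of 24 h (on this read-out lower numbers stand for stronger inhibition and higher numbers for weaker inhibition), at 1200 nM. Compound 1 `CNc1ncnc2c(CNc3cc(NC(=O)c4ccc(Cl)c(C(F)(F)F)c4)ccc3C)cccc12` gives 9700 nM and compound 2 `CNc1ncnc2c(CNc3cc(NC(=O)c4ccc(Br)s4)ccc3C)cccc12` gives 10500 nM, the two differing by a 1.1-fold higher number from compound 1 to compound 2 (0.03 log units; within the scatter). The change to compound 4 `CNc1ncnc2c(CNc3cc(NC(=O)c4cc(=O)c5ccccc5o4)ccc3C)cccc12` is a group of 11 heavy atoms (9 carbon, 2 oxygen; one six-membered aromatic ring of carbon only, one six-membered aromatic ring with 1 hetero atom) in place of a group of 6 heavy atoms (4 carbon, 1 nitrogen, 1 oxygen; one five-membered aromatic ring with 2 hetero atoms), on a carbonyl carbon. Both earlier swaps of the group on this carbonyl carbon bear on it: an 8.1-fold lower number from compound 1 to compound 3 (0.91 log units; beyond the scatter) and an 8.8-fold lower number from compound 2 to compound 3 (0.94 log units; beyond the scatter), each showing that the smaller five-membered group on this carbonyl carbon gave a lower number than a larger aromatic group. Compound 4 carries the largest group of the four at that place, so a higher number is expected, with a step of about a 4.2-fold higher number from compound 3 to compound 4 (0.62 log units; beyond the scatter). Compound 4 is therefore estimated at 5000 nM, within a range of 1500 nM to 20000 nM.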

Compound 4, half-maximal inhibitory concentration: 6 nM
Compound 4: the middle estimate sits 830-fold (2.92 log units) above what was measured; measured number outside the range, below it.
By their numbers in this assay, from the lowest: compound 4; then compound 3; then compounds 1 and 2 (each within the scatter of the next).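

In this assay, the size of the group on this carbonyl carbon does not by itself set the number: the largest group of the four gives a 200-fold lower number from compound 3 to compound 4 (2.30 log units; beyond the scatter). Heavy-atom count does not settle it either, since the 4-chloro-3-(trifluoromethyl)phenyl group has the same count as the group that replaces it, yet the swap gives a 1600-fold lower number from compound 1 to compound 4 (3.21 log units; beyond the scatter). Replacing 5-bromothiophen-2-yl gives a similarly large step, a 1800-fold lower number from compound 2 to compound 4 (3.24 log units; beyond the scatter).

Nothing available explains this large gain. As far as these compounds go, it also remains open whether the low number would survive an amine or a carboxylic acid added to the entering group.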